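The source may report more compounds than this note shows. Statements on the series, on what has been measured and on what is new or still open speak of the compounds shown alone.

In a functional assay on Huh-7 cells (Homo sapiens) for cytotoxicity, read by MTT assay, with a stated time of 72 h (a higher number here means that more compound is tolerated, a lower number that less compound is tolerated), three compounds sharing one core have been measured. Compound 1 `CCS(=O)(=O)N1CCC2(CC1)OOC1(CCCC1)OO2` gives > 100 ug/mL, which is a limit and not a number. Compound 2 `CCCS(=O)(=O)N1CCC2(CC1)OOC1(CCCC1)OO2` gives > 100 ug/mL, also a limit. Compound 3 `O=S(=O)(CCCCl)N1CCC2(CC1)OOC1(CCCC1)OO2` gives > 100 ug/mL, again a limit. Compound 4 `COc1ccc(S(=O)(=O)N2CCC3(CC2)OOC2(CCCC2)OO3)cc1` carries 4-methoxyphenyl in place of 3-chloropropyl on a sulfonyl sulfur. The measured steps, a step that the two limits leave unreadable from compound 1 to compound 2, a step that the two limits leave unreadable from compound 1 to compound 3 and a step that the two limits leave unreadable from compound 2 to compound 3, concern only the saturated chain, and none has a readable size. Because of the limit of > 100 ug/mL in this assay, at which 3 of the 3 values shown sit, compound 3 offers no number to start from, and no step beyond the scatter is expected in this assay. Compound 4 is estimated at 130 ug/mL, within an expected range of 60 ug/mL to 300 ug/mL. This estimate means an expected step that the limit leaves unreadable from compound 3 to compound 4.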

Compound 4, half-maximal cytotoxic concentration: > 100 ug/mL
Compound 4: a limit, no number; the forecaster's own chance of this, stated with the estimate: 70%; the middle value does not contradict the limit.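

No step from compound 1, compound 2 or compound 3 to compound 4 can be read, because all of these values are limits and not numbers: the limit of > 100 ug/mL in this assay, at which 4 of the 4 values shown sit.

The compounds shown leave open whether ethyl, propyl, 3-chloropropyl and 4-methoxyphenyl on the sulfonyl sulfur differ at all in this assay.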